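The source may hold more compounds than are shown below. What is called first, only, known or untested is meant among the compounds shown, and "the series" means these compounds.

In a functional assay on U-87MG ATCC cells for antiproliferative activity against U-87 MG (Homo sapiens), read by MTT assay, with a stated time of 48 h, tested at 100 uM (on this read-out higher numbers stand for a weaker effect at the one concentration tested and lower numbers for a stronger effect), the three measured compounds stand as follows:

compound 1, `Cc1nc(-c2ccc(Cl)cc2)sc1C(=O)CSc1nc(-c2cccc(Cl)c2)c(C#N)c(=O)[nH]1`, gives 12.5%
compound 2, `Cc1nc(-c2ccccc2)sc1C(=O)CSc1nc(-c2cccc(Cl)c2)c(C#N)c(=O)[nH]1`, gives 10%
compound 3, `Cc1nc(-c2ccccc2)sc1C(=O)CSc1nc(-c2ccc(Cl)cc2)c(C#N)c(=O)[nH]1`, gives 22.5%

Compounds 2 and 3 have the same atoms joined differently: 4-chlorophenyl in place of 3-chlorophenyl on an aromatic carbon. That rearrangement gives the step of a number 12.5 percentage points higher from compound 2 to compound 3 (beyond the scatter), so compound 3 has the highest number of the three, though its gap to compound 1 stays within the scatter.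

The second change appears twice. From compound 2 to compound 1 it reads (chloro in place of hydrogen on an aromatic carbon), and the step it made was a number 2.5 percentage points higher from compound 2 to compound 1 (within the scatter). From compound 3 to compound 4, `Cc1nc(-c2ccc(Cl)cc2)sc1C(=O)CSc1nc(-c2ccc(Cl)cc2)c(C#N)c(=O)[nH]1`, the change is chloro in place of hydrogen on an aromatic carbon; the two places are described in the same words, so this is the same change on a different starting compound.

Compound 4 is estimated to move by a number 2.5 percentage points higher from compound 3 to compound 4 (within the scatter), because the earlier step of a number 2.5 percentage points higher from compound 2 to compound 1 (within the scatter) was small. For compound 4 the expected value is 25%, with a likely range from 12% to 40%.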

Compound 4, a percentage reported as activity, at one concentration (the size of the read-out at that concentration, not a potency): 12.8%
Beside the measured number, compound 4's estimate is 12.2 percentage points above it, and the stated range covers the measured number.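

Putting chloro in place of hydrogen, which turns phenyl into 4-chlorophenyl, gives a number 9.7 percentage points lower from compound 3 to compound 4 (within the scatter) in this assay, and this step cannot be told apart from the same change made earlier on another core: the same change on two cores in this assay, a number 2.5 percentage points higher (within the scatter) from compound 2 to compound 1 and a number 9.7 percentage points lower (within the scatter) from compound 3 to compound 4, 12.2 percentage points apart, within the scatter of two such steps. Moving from 3-chlorophenyl to 4-chlorophenyl gives a number 0.3 percentage points higher from compound 1 to compound 4 (within the scatter), and although only the earlier step of this kind lies beyond the scatter, the two steps also cannot be told apart: the same change on two cores in this assay, a number 12.5 percentage points higher (beyond the scatter) from compound 2 to compound 3 and a number 0.3 percentage points higher (within the scatter) from compound 1 to compound 4, 12.2 percentage points apart, within the scatter of two such steps. Neither change is therefore shown to behave differently from one core to the other, but this does not prove that either carries over unchanged, as each comparison rests on just two pairs of compounds read at a single concentration.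

The compounds shown leave open what an amine, a methoxy group or a carboxylic acid in place of the chloro would give. Going by these compounds, whether either change reads the same way at lower concentrations also remains open.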